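This account rests on a few compounds, and the source may have more. Where it says the series, first, only, none or still open, it means among the compounds named here.

Measured compounds:
- compound 1 `CCCCOC(=O)Nc1ccc(S(=O)(=O)N2C[C@H](c3ccccc3)NC2=O)cc1CC` gives 200 nM in a functional assay on HCT-116 cells (Homo sapiens) for cytotoxicity, read by MTT assay; on this read-out higher numbers stand for weaker inhibition and lower numbers for stronger inhibition
- compound 2 `CCOC(=O)Nc1ccc(S(=O)(=O)N2C(=O)N[C@@H](c3ccccc3)C2C)cc1Cl` gives 5500 nM in this assay
- compound 3 `CCOC(=O)Nc1ccc(S(=O)(=O)N2C[C@H](c3ccccc3)NC2=O)cc1Cl` gives 200 nM in this assay

Compound 1 stands level with compound 3 at the digits shown, and the two together hold the lowest numbers of the three. Among the measured compounds shown here, compound 2 sits far apart from both: the single measured step, a 28-fold lower number from compound 2 to compound 3 (1.44 log units; beyond the scatter), comes from removing a methyl from the saturated ring and is large.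

The step to compound 4 `CCc1cc(S(=O)(=O)N2C[C@H](c3ccccc3)NC2=O)ccc1NC(=O)OC` is of a different kind: hydrogen in place of propyl on a saturated chain carbon bound to an oxygen next to a carbonyl group. It shortens the chain on the carbamate oxygen and leaves the saturated ring untouched, so the step from compound 2 to compound 3 says nothing direct about it. The only hint is indirect: compound 1 and compound 3 carry different chains on that same oxygen, along with a second difference on the aromatic ring, and yet they give the same number. For the measured compounds named here, with no measured step on this change alone, the expectation is for a small movement, within the scatter, in either direction.

Compound 4 is therefore expected to come out at about 250 nM, within a range of 100 nM to 700 nM, which means an expected step of a 1.3-fold higher number from compound 1 to compound 4 (0.10 log units; within the scatter).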

Compound 4, half-maximal inhibitory concentration: 200 nM
Beside the measured number, compound 4's estimate is 1.3-fold (0.10 log units) above it, within the range that was stated.
By their numbers in this assay, from the lowest: compounds 1, 3 and 4 (each within the scatter of the next); then compound 2.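

Going from butoxy to methoxy on the carbamate gives no change at the digits printed from compound 1 to compound 4 (within the scatter) in this assay, and this pair gives a reading on the chain alone. The chain on that oxygen is the only place where the two compounds differ. The earlier compounds shown here could offer only a hint, since the two that carried different chains there also differed on the aromatic ring. The result shows that, in this setting, butyl and methyl on this oxygen cannot be told apart in this cell read-out, but nothing available explains why the chain can shrink with no visible effect.

The compounds shown cover only butyl and methyl at this place, so it remains open whether a longer chain such as octyl, a benzyl group, or a chain ending in an amine or a carboxylic acid would leave the number where it stands. From the compounds shown here alone, it also remains open whether the same change would read the same way with a chlorine on the aromatic ring instead of the ethyl group that compound 1 and compound 4 share.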